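The source may report more compounds than this note shows. Statements on the series, on what has been measured and on what is new or still open speak of the compounds shown alone.

Measured compounds:
- compound 1, `O=C(Nc1cccnc1)c1ccc(Cl)cc1`, 10200 nM
- compound 2, `O=C(Nc1cccnc1)c1ccc(F)c(F)c1`, 5920 nM

Both were run in an assay on V79 cells for inhibition of cytochrome P450 11B1, mitochondrial (Homo sapiens); on this read-out higher numbers stand for weaker inhibition and lower numbers for stronger inhibition. On those two numbers compound 2 sits at the low end, but its gap to compound 1 falls within the scatter of repeated measurement, so the two are not separated by this read-out. Among the compounds with values here, no single-change step between measured compounds is available, so nothing is known yet about how much any one substitution on this core shifts this assay.

Compound 3, `O=C(Nc1cccnc1)c1cc(F)c(F)cc1F`, has not been measured. Compared with compound 2 the change is fluoro in place of hydrogen on an aromatic carbon, so the same amide and the same pyridine remain and only a hydrogen on the fluorinated ring is exchanged.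

With no comparable step shown, the expectation is a step within the scatter, if anything toward a somewhat smaller number: a 1.3-fold lower number from compound 2 to compound 3 (0.12 log units; within the scatter). Compound 3 is therefore estimated at 4500 nM, with a range from 1500 nM to 13000 nM.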

Compound 3, half-maximal inhibitory concentration: 16100 nM
Compound 3: the middle estimate sits 3.6-fold (0.55 log units) below what was measured; measured number above the stated range.
By their numbers in this assay, from the lowest: compounds 2, 1 and 3 (each within the scatter of the next, the first and the last beyond it).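

Within the data shown here, this is the only single-change step on the shared core so far: in this assay, fluoro in place of hydrogen on the aromatic carbon ortho to a group of 9 heavy atoms gives a 2.7-fold higher number from compound 2 to compound 3 (0.43 log units; beyond the scatter) and thus a modest move toward weaker inhibition. This position therefore responds to the change, which compound 1 and compound 2 could not show, as no single change links them. Nothing available offers a measured basis for explaining this shift.

Still open, going by these compounds, is whether the shift is particular to fluoro: a chloro, a methoxy or an amine on the same aromatic carbon would distinguish a fluoro-specific step from one shared by other groups. Also open, on these data alone, is whether the same change on the core of compound 1 gives a step of similar size.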